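A few compounds are considered here, and "the series" means these few. Any claim that something is new, unique, unknown or untested is made for them only; others in the source may bear on it.

Measured compounds:
compound 1 `COc1cc2nccc(Oc3ccc(NC(=O)c4nnc(-c5ccc(F)cc5)o4)cc3)c2cc1OC` — 5140 nM
compound 2 `COc1cc2c(Oc3ccc(NC(=O)C4(c5nnc(-c6ccc(F)cc6)o5)CC4)cc3F)ccnc2cc1OCCCN1CCC(C)CC1` — 120 nM

Compound 1 stands at the highest number of the two, in a functional assay on A549 cells (Homo sapiens) for antiproliferative activity, read by MTT assay, with a stated time of 72 h (a lower number here means a stronger inhibitor, a higher number a weaker inhibitor), giving 5140 nM. Compound 2, which carries a longer basic chain along with other differences, gives 120 nM, a gap well beyond the scatter. Compound 3 `COc1cc2c(Oc3ccc(NC(=O)c4nnc(-c5ccc(F)cc5)o4)cc3)ccnc2cc1OCCCN1CCC(C)CC1` has not yet been measured. It departs from compound 1 in a single place: 2-(4-methylpiperidin-1-yl)ethyl in place of hydrogen on a saturated chain carbon bound to an oxygen on an aromatic ring. Among the compounds with values here, no measured pair isolates this change on its own, so its size is not known directly. Because compound 2 gives 120 nM while bearing a related chain in the same region, the change is expected to lower the number for compound 3 in this assay, and the step of a 4.3-fold lower number from compound 1 to compound 3 (0.63 log units; beyond the scatter) is expected to fall beyond the scatter. The estimate for compound 3 is 1200 nM, with a range from 350 nM to 4000 nM.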

Compound 3, half-maximal inhibitory concentration: 2730 nM
Compound 3: the middle estimate sits 2.3-fold (0.36 log units) below what was measured; the range from low to high includes it.
By their numbers in this assay, from the lowest: compound 2; then compounds 3 and 1 (each within the scatter of the next).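

Measured in this assay, the exchange of methoxy for 3-(4-methylpiperidin-1-yl)propoxy on the core of compound 1 gives a 1.9-fold lower number from compound 1 to compound 3 (0.27 log units; within the scatter), so at this position the added six-membered non-aromatic ring and its chain do not move the number beyond the scatter. Compound 3 differs from compound 2 in more than one place, and the value of 120 nM for compound 2 cannot be credited to this chain alone. Nothing shown here gives a reason for this result.

The compounds shown leave open whether a morpholine or a piperazine in place of the 4-methylpiperidin-1-yl group, or a shorter or longer chain, would give a step beyond the scatter. They also leave open how the same chain behaves on a core carrying the other features of compound 2.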